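A few compounds are considered here, and "the series" means these few. Any claim that something is new, unique, unknown or untested is made for them only; others in the source may bear on it.

Measured in a functional assay on CCRF-CEM cells (Homo sapiens) for cytotoxicity, read by XTT assay, with a stated time of 3 days; on this read-out higher numbers stand for weaker inhibition and lower numbers for stronger inhibition:

Compound 1, `OC[C@H]1O[C@@H](n2cc(F)c3c(-c4ccoc4)ncnc32)[C@H](O)[C@@H]1O`: 1000 nM
Compound 2, `OC[C@H]1O[C@@H](n2cc(F)c3c(-c4ccsc4)ncnc32)[C@H](O)[C@@H]1O`: 560 nM
Compound 3, `OC[C@H]1O[C@@H](n2cc(Cl)c3c(-c4ccoc4)ncnc32)[C@H](O)[C@@H]1O`: 1100 nM

Compound 1 and compound 2 share a core and differ in one place, (thiophen-3-yl in place of furan-3-yl on an aromatic carbon). That exchange gave a 1.8-fold lower number from compound 1 to compound 2 (0.25 log units; within the scatter). Compound 3 carries a different core; how it departs from compound 1 is chloro in place of fluoro on an aromatic carbon, and the two cores are set apart by a 1.1-fold higher number from compound 1 to compound 3 (0.04 log units; within the scatter). All three measured values lie within the usual scatter of one another, so none of them can be put in front of the others.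

Compound 4, `OC[C@H]1O[C@@H](n2cc(Cl)c3c(-c4ccsc4)ncnc32)[C@H](O)[C@@H]1O`, has not been measured in this assay. It stands to compound 3 as compound 2 stands to compound 1: the difference is thiophen-3-yl in place of furan-3-yl on an aromatic carbon, and the surroundings of the exchanged group are described in the same words for both pairs, so it is the same change made on the other core. Because compound 3 gives 1100 nM and the earlier exchange gave a 1.8-fold lower number from compound 1 to compound 2 (0.25 log units; within the scatter), the step from compound 3 to compound 4 is expected to be about a 1.8-fold lower number from compound 3 to compound 4 (0.25 log units; within the scatter), a shift of the same order as the one seen before and again one that would sit within the scatter. Compound 4 is therefore estimated at 620 nM, with a plausible range from 300 nM to 1300 nM, close to what compound 2 gives at 560 nM.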

Compound 4, half-maximal inhibitory concentration: 1000 nM
Estimate against measurement, compound 4: 1.6-fold (0.21 log units) below; measured number inside the range.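

On the chloro-bearing core in this assay, thiophen-3-yl in place of furan-3-yl gave a 1.1-fold lower number from compound 3 to compound 4 (0.04 log units; within the scatter), and this agrees with the same exchange on the fluoro-bearing core: the same change on two cores in this assay, a 1.8-fold lower number (0.25 log units; within the scatter) from compound 1 to compound 2 and a 1.1-fold lower number (0.04 log units; within the scatter) from compound 3 to compound 4, 1.6-fold (0.21 log units) apart, within the scatter of two such steps. Chloro in place of fluoro, this time with thiophen-3-yl in place, gave a 1.8-fold higher number from compound 2 to compound 4 (0.25 log units; within the scatter), and this likewise agrees with the same exchange made with furan-3-yl in place: the same change on two cores in this assay, a 1.1-fold higher number (0.04 log units; within the scatter) from compound 1 to compound 3 and a 1.8-fold higher number (0.25 log units; within the scatter) from compound 2 to compound 4, 1.6-fold (0.21 log units) apart, within the scatter of two such steps. The two exchanges thus behave alike on the two cores, but every step among these four compounds lies within the scatter, so this shows only that neither exchange produced a readable shift on either core, not that a real effect of either change carries from one core to another.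

The compounds shown leave open whether an amine or a phenyl ring on the carbon that holds furan-3-yl, or a bromo or methyl group in place of the halogen, would give a step beyond the scatter. They also leave open whether a step of that kind would keep its size when carried to the other core, which is the test these four compounds cannot provide.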